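Halogen swap on the benzyl ring of compound 3

The source may hold more compounds than are shown below. What is called first, only, known or untested is meant among the compounds shown, and "the series" means these compounds.

In a functional assay on MCF7 cells (Homo sapiens) for inhibition, read by MTT assay, with a stated time of 48 h, tested at 10 uM (a lower number here means less inhibition of growth, a higher number more inhibition of growth at the concentration tested), compound 3 `O=C(/C=C/c1ccc(OCc2cn(Cc3ccc(Br)cc3)nn2)cc1)c1ccc([N+](=O)[O-])cc1` gives 18%, and compound 2 `O=C(/C=C/c1ccc(OCc2cn(Cc3cccc(Br)c3)nn2)cc1)c1ccc([N+](=O)[O-])cc1` gives 12%, a number within the scatter of it; compound 1 `O=C(/C=C/c1ccc(OCc2cn(Cc3ccccc3)nn2)cc1)c1ccc([N+](=O)[O-])cc1` is reported as "not active" (no number reported). Within the data shown here, the single measured step, a number 6 percentage points higher from compound 2 to compound 3 (within the scatter), stays inside the scatter. Compound 4 `O=C(/C=C/c1ccc(OCc2cn(Cc3ccc(F)cc3)nn2)cc1)c1ccc([N+](=O)[O-])cc1` differs from compound 3 by fluoro in place of bromo on an aromatic carbon. Among the measured compounds shown here, no measured step exchanges one halogen for another, so the expectation rests only on the narrow spread seen between compound 2 and compound 3. For compound 4 the step of a number 3 percentage points lower from compound 3 to compound 4 (within the scatter) is therefore expected to remain within the scatter, with no direction favoured. Compound 4 is estimated at 15%, with a range from 4% to 26%.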

Compound 4, percent growth inhibition at one concentration: 38%
Compound 4: middle estimate off by 23 percentage points, on the low side; the measured number lies above the stated range.
By their numbers in this assay, from the lowest: compounds 2 and 3 (each within the scatter of the next); then compound 4.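

In this assay, fluoro in place of bromo on this aromatic carbon gives a number 20 percentage points higher from compound 3 to compound 4 (beyond the scatter), so the identity of the halogen here changes the result by more than the scatter. The 4-fluorophenyl group also stands clear of the 3-bromophenyl group, with a number 26 percentage points higher from compound 2 to compound 4 (beyond the scatter). No evidence at hand accounts for this rise.

From the compounds shown here alone, whether chloro or a methoxy group at this place would match fluoro remains open. So does the size of any gain over the unsubstituted benzyl group, as compound 1 has no number.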